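Working notes: aryl exchange from compound 2 to compound 3

The source may hold more compounds than are shown below. What is called first, only, known or untested is meant among the compounds shown, and "the series" means these compounds.

Of the compounds shown here, two have numbers so far. In a functional assay on HeLa cells (Homo sapiens) for cytotoxicity, read by MTT assay, with a stated time of 24 h (on this read-out lower numbers stand for stronger inhibition and higher numbers for weaker inhibition), compound 1 (`COc1ccc(/C=C(\C#N)C(=O)N/N=C(\C)c2c(O)c3ccc(O)cc3oc2=O)cc1OC`) gives 13500 nM and compound 2 (`C/C(=N\NC(=O)/C(C#N)=C/c1ccccc1[N+](=O)[O-])c1c(O)c2ccc(O)cc2oc1=O`) gives 10300 nM on the same read-out. Compound 2 therefore stands level with compound 1, since the gap between them does not exceed the scatter.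

Compound 3 (`C/C(=N\NC(=O)/C(C#N)=C/c1cccc(Br)c1)c1c(O)c2ccc(O)cc2oc1=O`) keeps the shared core and changes one group: 3-bromophenyl in place of 2-nitrophenyl on a double-bonded chain carbon bound to a double-bonded chain carbon in words, 3-bromophenyl in place of 2-nitrophenyl on a double-bonded chain carbon bound to a double-bonded chain carbon.

Going by the values given here, one measured step bears on this change, as it falls at the same place. That step is a 1.3-fold lower number from compound 1 to compound 2 (0.12 log units; within the scatter) and it exchanges 3,4-dimethoxyphenyl for 2-nitrophenyl without leaving the scatter. Among the compounds with values here, the data hold no compound with a bromine on this group, so the basis is thin and the range must stay wide. The step expected in this assay is a 1.1-fold higher number from compound 2 to compound 3 (0.03 log units; within the scatter) and thus none beyond the scatter. The estimated value for compound 3 is 11000 nM (expected range 5000 nM to 24000 nM).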

Compound 3, half-maximal inhibitory concentration: 24300 nM
The estimate for compound 3 lay 2.2-fold (0.34 log units) below the measured number; measured number above the stated range.
By their numbers in this assay, from the lowest: compounds 2, 1 and 3 (each within the scatter of the next, the first and the last beyond it).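

In this assay, going by these compounds alone, this position now gives a first step beyond the scatter, modest in size: a 2.4-fold higher number from compound 2 to compound 3 (0.37 log units; beyond the scatter) with 3-bromophenyl in place of 2-nitrophenyl on a double-bonded chain carbon bound to a double-bonded chain carbon. The exchange of 3,4-dimethoxyphenyl for 3-bromophenyl at the same place stays within the scatter (a 1.8-fold higher number from compound 1 to compound 3 (0.26 log units; within the scatter)), so the effect of entering 3-bromophenyl depends on the group it replaces. The position therefore responds to a change of aryl group, but only the two ends of the series separate, and compound 1 cannot be told apart from either compound 2 or compound 3. Nothing measured on these compounds accounts for the difference between the aryl groups.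

On these data alone, each aryl group here is a single example, so it remains open whether the step follows from the entering bromine or from the departing nitro group. An unsubstituted phenyl, a chlorine in place of the bromine, or an amine in place of the nitro group at this place would help to separate these two readings.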